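The source may report more compounds than this note shows. Statements on the series, on what has been measured and on what is new or still open speak of the compounds shown alone.

Measured so far in an ADME assay for permeability, using PAMPA, with a stated time of 30 min, at pH 7.4; a lower number here means that the compound crosses the layer more slowly, a higher number that the compound crosses the layer faster:
compound 1 `CCC(CC)c1ccc2c(NCCCNCc3ccco3)ccnc2c1`: 23 10^-6 cm/s
compound 2 `CN(C)c1cccc(Oc2ccc3c(NCCCNCc4ccco4)ccnc3c2)c1`: 317 10^-6 cm/s

Compound 2 stands highest of these two numbers; the nearest is compound 1, and the step of a 14-fold higher number from compound 1 to compound 2 (1.14 log units; beyond the scatter) was large. Compound 3 `N#Cc1ccc(Cc2ccc3c(NCCCNCc4ccco4)ccnc3c2)cc1` differs from compound 2 by 4-cyanobenzyl in place of 3-(dimethylamino)phenoxy on an aromatic carbon. Within the data shown here, only that one step bears on this position, and it shows that swapping the group there can move this assay strongly. Among the measured compounds shown here, with no closer precedent, a moderate decrease is expected, the estimate being the step of a 2.1-fold lower number from compound 2 to compound 3 (0.32 log units; beyond the scatter). Compound 3 is therefore expected to give 150 10^-6 cm/s, within 50 10^-6 cm/s to 400 10^-6 cm/s.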

Compound 3, apparent permeability in the ADME assay: 23 10^-6 cm/s
Beside the measured number, compound 3's estimate is 6.5-fold (0.81 log units) above it, and the stated range ends above it.
By their numbers in the ADME assay, from the lowest: compounds 1 and 3 (each within the scatter of the next); then compound 2.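

In the ADME assay the high number belongs to 3-(dimethylamino)phenoxy alone at this position: a 14-fold lower number from compound 2 to compound 3 (1.14 log units; beyond the scatter), whereas no change at the digits printed from compound 1 to compound 3 (within the scatter), so 4-cyanobenzyl and pentan-3-yl cannot be told apart here. In a physicochemical assay for acid dissociation, compound 2 gives 9.28 and compound 3 gives 9.47, and with a number 0.19 log units higher from compound 2 to compound 3 (within the scatter) this read-out does not separate the pair. Nothing available explains the gap in the ADME assay. As far as these compounds go, compound 3 replaces the ring oxygen link and the dimethylamino group together, so which of them matters stays open; an unsubstituted phenoxy or a 3-(dimethylamino)benzyl would separate the two.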